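Swapping the Aryl Isopropyl for Trifluoromethoxy

The source may hold more compounds than are shown below. What is called first, only, known or untested is meant among the compounds shown, and "the series" means these compounds.

Compound 1 `CC(C)c1ccc(NC(=O)N2CCN(c3ncccc3Cl)CC2)cc1` is the starting point. In a functional assay on HEK293 cells for antagonist activity at transient receptor potential cation channel subfamily V member 1 (Rattus norvegicus) (a higher number here means a weaker inhibitor, a lower number a stronger inhibitor), compound 1 gives 11.5 nM, the lowest number of the three compounds measured. Compound 2 `CCc1cccnc1N1CCN(C(=O)Nc2ccc(C(C)C)cc2)CC1` gives 230 nM and compound 3 `CC(C)c1ccc(NC(=O)N2CCN(c3ncccc3C=O)CC2)cc1` gives 201 nM. The measured steps all change the group on the pyridine part of the shared core: a 20-fold higher number from compound 1 to compound 2 (1.30 log units; beyond the scatter), a 17-fold higher number from compound 1 to compound 3 (1.24 log units; beyond the scatter), and a 1.1-fold lower number from compound 2 to compound 3 (0.06 log units; within the scatter).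

Compound 4 `O=C(Nc1ccc(OC(F)(F)F)cc1)N1CCN(c2ncccc2Cl)CC1` differs from compound 1 elsewhere, on the other aromatic ring: trifluoromethoxy in place of isopropyl on an aromatic carbon. For the measured compounds named here, none of the measured steps touches this position, so they say nothing directly about how this change will turn out; the only firm anchor is the value of compound 1. Without a comparable step, the expectation is a modest move, if any, beyond the scatter. Compound 4 is therefore expected to give about 20 nM in this assay, with a range from 5 nM to 80 nM. That estimate corresponds to a 1.7-fold higher number from compound 1 to compound 4 (0.24 log units; within the scatter).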

Compound 4, half-maximal inhibitory concentration: 93.2 nM
Estimate against measurement, compound 4: 4.7-fold (0.67 log units) below; measured number above the stated range.
By their numbers in this assay, from the lowest: compound 1; then compound 4; then compounds 3 and 2 (each within the scatter of the next).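

With the chloro group held fixed, trifluoromethoxy in place of isopropyl on the six-membered aromatic ring of carbon only raises the number in this assay (an 8.1-fold higher number from compound 1 to compound 4 (0.91 log units; beyond the scatter)). For the compounds shown here, the earlier compounds varied only the group on the other aromatic ring, so this is the first sign that activity also responds to a change at this end of the molecule, and of these two groups, isopropyl gives the stronger inhibitor. No measurement at hand explains this rise.

From the compounds shown here alone, whether a tert-butyl group or a trifluoromethyl group at this position would give a number closer to that of compound 1 remains open. Going by these compounds, it is also open whether the same swap would cost as much with ethyl or formyl in place of chloro.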